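Notes on the substituent at the saturated ring carbon

This account rests on a few compounds, and the source may have more. Where it says the series, first, only, none or still open, it means among the compounds named here.

compound 1, `CC(C)CC1C(=O)N(C)c2cnc(Nc3ccc(S(N)(=O)=O)cc3)nc2N1C`: in an assay on Sf9 cells for inhibition of serine/threonine-protein kinase 4 (Homo sapiens), read by luminescence and ADP-Glo, with a stated time of 1 h, in the presence of a further agent that is not named here (a higher number here means a weaker inhibitor, a lower number a stronger inhibitor), compound 1 gives 77 nM
compound 2, `CCc1ccccc1C1C(=O)N(C)c2cnc(Nc3ccc(S(N)(=O)=O)cc3)nc2N1C`: in this assay compound 2 gives 51 nM
compound 3, `CN1C(=O)C(c2c(F)cccc2F)N(C)c2nc(Nc3ccc(S(N)(=O)=O)cc3)ncc21`: in this assay compound 3 gives 42 nM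

Compound 3 holds the lowest of the three numbers, but the other two sit within the scatter of it: a 1.2-fold lower number from compound 2 to compound 3 (0.08 log units; within the scatter) and a 1.8-fold lower number from compound 1 to compound 3 (0.26 log units; within the scatter). The remaining pair behaves the same way, a 1.5-fold lower number from compound 1 to compound 2 (0.18 log units; within the scatter). Every exchange made so far at the saturated ring carbon has left the number in this assay essentially unchanged, whether the group was a branched chain, an alkyl-bearing aromatic ring or a fluorine-bearing aromatic ring.

Compound 4, `CN1C(=O)C(Cc2ccccc2)N(C)c2nc(Nc3ccc(S(N)(=O)=O)cc3)ncc21`, has not yet been measured. It differs from compound 3 in one place: benzyl in place of 2,6-difluorophenyl on a saturated ring carbon. For the measured compounds named here, no measured pair exchanges a directly attached aromatic ring for a benzyl group, so the only steps that bear on this change are the three exchanges at the same carbon, each of them within the scatter. A step in this assay beyond the scatter is therefore not expected in either direction. The expected step is a 1.3-fold higher number from compound 3 to compound 4 (0.12 log units; within the scatter). For compound 4 the estimate in this assay is 55 nM, with a range from 20 nM to 160 nM.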

Compound 4, half-maximal inhibitory concentration: > 10000 nM
Compound 4 was reported as a limit; the forecaster's own chance of this, stated with the estimate: 3%; middle value at least 180-fold (2.25 log units) from the limit.
By their numbers in this assay, from the lowest: compounds 3, 2 and 1 (each within the scatter of the next). At a limit, above all of these: compound 4.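

In this assay, for the compounds shown here, the saturated ring carbon proves far less forgiving than the earlier compounds suggested, with an at least 230-fold higher number from compound 3 to compound 4 (2.37 log units; beyond the scatter), an at least 190-fold higher number from compound 2 to compound 4 (2.29 log units; beyond the scatter) and an at least 120-fold higher number from compound 1 to compound 4 (2.11 log units; beyond the scatter). Compound 4 stands at a limit, not a number, so these steps give only the smallest size the change can have: the limit of > 10000 nM in this assay, at which 1 of the 4 values shown sits.

The counts do not separate the groups: 2,6-difluorophenyl and benzyl each hold one six-membered aromatic ring of carbon only, with no hydrogen-bond donors, no hydrogen-bond acceptors and no net charge, and a saturated chain carbon on the ring carbon is also present in compound 1, so neither the aromatic ring alone nor the chain carbon alone tracks with the change.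

What remains open is how narrow the boundary is: only the combination of chain carbon and phenyl is shown, in a single group. A benzyl with fluorine on its ring, a longer chain ending in phenyl, or a benzyl carrying an amine would show whether the drop belongs to benzyl in general or to unsubstituted benzyl only.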